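The source may report more compounds than this note shows. Statements on the series, on what has been measured and on what is new or still open speak of the compounds shown alone.

Within the data shown here, only two compounds have been measured so far in a functional assay on K562 cells (Homo sapiens) for cytotoxicity, read by ELISA, with a stated time of 4 days; on this read-out higher numbers stand for weaker inhibition and lower numbers for stronger inhibition. In it, compound 1 `Clc1ccc(-c2cc(-c3ccco3)cc(-c3ccc(Cl)s3)n2)cc1` gives 10500 nM and compound 2 `Cc1ccc(-c2cc(-c3ccoc3)cc(-c3ccc(Cl)s3)n2)cc1` gives 17900 nM. These two values lie within the usual scatter of each other, so compound 1 stands level with compound 2 and neither can be ranked ahead of the other.

Compound 3 `Clc1ccc(-c2cc(-c3ccoc3)cc(-c3ccc(Cl)s3)n2)cc1` has not yet been measured. It has the same atoms as compound 1, joined differently, with furan-3-yl in place of furan-2-yl on an aromatic carbon. That carbon lies opposite the ring nitrogen. The furan ring stays, and only its point of attachment changes.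

No measured pair shows the effect of this swap, so the data give no reason to expect a direction in this assay. The expected step, a 1.1-fold higher number from compound 1 to compound 3 (0.06 log units; within the scatter), is estimated to stay within the scatter, and this expectation starts from the value of compound 1 at 10500 nM. For compound 3 the estimated value is 12000 nM, with an expected range from 5500 nM to 26000 nM.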

Compound 3, half-maximal inhibitory concentration: 19600 nM
Compound 3: the middle estimate sits 1.6-fold (0.21 log units) below what was measured; the range from low to high includes it.
By their numbers in this assay, from the lowest: compounds 1, 2 and 3 (each within the scatter of the next).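

In this assay, among these compounds, this is the first measured pair for furan-3-yl in place of furan-2-yl on the aromatic carbon opposite the ring nitrogen. It gives a 1.9-fold higher number from compound 1 to compound 3 (0.27 log units; within the scatter) and so shows that, among these compounds, changing the point of attachment of the furan leaves no difference that can be told apart from repeat measurement. Among the compounds shown here, compound 3 also supplies the first pair for chloro in place of methyl on an aromatic carbon, and a 1.1-fold higher number from compound 2 to compound 3 (0.04 log units; within the scatter) again leaves the two compounds level, so in this assay neither single change separates its pair, and nothing at hand offers an explanation of these results.

Every compound shown carries a furan on the carbon opposite the ring nitrogen, so it stays open whether a group of another kind there, such as an amine or a carboxylic acid, would move the number beyond the scatter. The 5-chlorothiophen-2-yl group is also the same throughout, which leaves open what a different group in its place, such as a longer chain, would do on this read-out.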